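This account rests on a few compounds, and the source may have more. Where it says the series, first, only, none or still open, it means among the compounds named here.

Compound 1 `COc1cc(-c2nn(-c3cccc(NC(=O)Nc4cc(C(F)(F)F)cc(C(F)(F)F)c4)c3)cc2-c2ccncc2)ccc1Cl` is measured in a functional assay on CCRF-CEM cells (Homo sapiens) for inhibition, read by sulforhodamine B assay, with a stated time of 48 h (a lower number here means a stronger inhibitor of growth, a higher number a weaker inhibitor of growth), and gives 2790 nM. Compound 2 `O=C(Nc1cccc(-n2cc(-c3ccncc3)c(-c3ccc(Cl)c(O)c3)n2)c1)Nc1cc(C(F)(F)F)cc(C(F)(F)F)c1` differs from it in one place, (hydrogen in place of methyl on an oxygen on an aromatic ring), and in this assay compound 2 gives 6780 nM. That change produced a 2.4-fold higher number from compound 1 to compound 2 (0.39 log units; beyond the scatter). Compound 3 `COc1cc(-c2nn(-c3cccc(NC(=O)Nc4ccc(Cl)c(C(F)(F)F)c4)c3)cc2-c2ccncc2)ccc1Cl` differs from compound 1 in its core, and the difference between the two cores is not broken down here. In this assay compound 3 reaches only a limit, > 32500 nM, a value that is not a number but (the limit of > 32500 nM in this assay, at which 1 of the 3 values shown sits). Compound 4 `O=C(Nc1cccc(-n2cc(-c3ccncc3)c(-c3ccc(Cl)c(O)c3)n2)c1)Nc1ccc(Cl)c(C(F)(F)F)c1` has not yet been measured; it stands to compound 3 as compound 2 stands to compound 1, through the same change, (hydrogen in place of methyl on an oxygen on an aromatic ring). The step in this assay is expected to be a step that the limit leaves unreadable from compound 3 to compound 4, resting on the earlier change from compound 1 that gave a 2.4-fold higher number from compound 1 to compound 2 (0.39 log units; beyond the scatter). Compound 4 is therefore estimated at 65000 nM, between 25000 nM and 200000 nM, most likely again reported only as a limit.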

Compound 4, concentration for total growth inhibition: 2700 nM
Compound 4: the middle estimate sits 24-fold (1.38 log units) above what was measured, and the stated range ends above it.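

Swapping methoxy for hydroxy gives an at least 12-fold lower number from compound 3 to compound 4 (1.08 log units; beyond the scatter) in this assay, whereas on the core of compound 1 the same swap moved the number the other way, so this change does not carry over unchanged between the two cores: the same change on two cores in this assay, a 2.4-fold higher number (0.39 log units; beyond the scatter) from compound 1 to compound 2 and an at least 12-fold lower number (1.08 log units; beyond the scatter) from compound 3 to compound 4, at least 29-fold (1.46 log units) apart, beyond the scatter of two such steps

Compound 3 reaches only a limit, so the exact size of its step stays unknown: the limit of > 32500 nM in this assay, at which 1 of the 4 values shown sits.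

Two pairs show that the outcome of this swap can depend on the core, but they do not show why, or what it would do on a third core.

As far as these compounds go, it remains open whether an amine or an ethoxy group in the same place would also behave differently on these two cores.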